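Swapping a Tetrazole for a Pyrimidine on Sulfur

A few compounds are considered here, and "the series" means these few. Any claim that something is new, unique, unknown or untested is made for them only; others in the source may bear on it.

Compound 1 `O=C(CSc1nnnn1-c1ccccc1)N/N=c1/scc(-c2ccc(Br)cc2)n1-c1ccccc1` and compound 2 `Cc1ccc(-c2cs/c(=N/NC(=O)CSc3nnnn3-c3ccccc3)n2-c2ccccc2)cc1` share one core and differ at a single aromatic carbon. In a functional assay on C6 cells (Rattus norvegicus) for cytotoxicity, read by MTT assay, with a stated time of 24 h, tested at 200 ug/mL (on this read-out higher numbers stand for a weaker effect at the one concentration tested and lower numbers for a stronger effect), compound 1 gives 20.4%, and compound 2 gives 22.2%; with a number 1.8 percentage points higher from compound 1 to compound 2 (within the scatter), the two stand together, compound 2 alongside compound 1 within the scatter. Compound 3 `Cc1ccc(-c2cs/c(=N/NC(=O)CSc3ncccn3)n2-c2ccccc2)cc1` differs from compound 2 by pyrimidin-2-yl in place of 1-phenyl-1H-tetrazol-5-yl on a sulfur. Among the measured compounds shown here, no measured step touches the group on the sulfur, so nothing measured bears on this change. The step of a number 2.8 percentage points higher from compound 2 to compound 3 (within the scatter) is therefore expected to be small, of no clear direction. Compound 3 is estimated at 25%, with a range from 10% to 45%.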

Compound 3, a percentage reported as activity, at one concentration (the size of the read-out at that concentration, not a potency): 43.7%
Estimate against measurement, compound 3: 18.7 percentage points below, within the range that was stated.
By their numbers in this assay, from the lowest: compounds 1 and 2 (each within the scatter of the next); then compound 3.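

The group on the sulfur matters: in this assay, pyrimidin-2-yl in place of 1-phenyl-1H-tetrazol-5-yl gives a number 21.5 percentage points higher from compound 2 to compound 3 (beyond the scatter), which means a weaker effect at the one concentration tested. The earlier swap of methyl for bromo stayed within the scatter, so this is the first change shown that clearly moves the read-out. No available evidence accounts for this shift.

Going by these compounds, whether 1-methyl-1H-tetrazol-5-yl on the same sulfur would stay with compound 2 or move toward compound 3 remains open. Also open, on these data alone, is whether this change would have the same effect with bromo in place of methyl.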